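Piperazine nitrogen substituents on the benzofuranyl ketone series

This account rests on a few compounds, and the source may have more. Where it says the series, first, only, none or still open, it means among the compounds named here.

Measured compounds:
compound 1 `CCN(CC)c1ccc2cc(C(=O)c3ccc(N4CCN(C(=O)CN5CCNCC5)CC4)cc3)oc2c1` — 1220 nM
compound 2 `CCN(CC)c1ccc2cc(C(=O)c3ccc(N4CCN(C(=O)CN5CCN(C(=O)CCl)CC5)CC4)cc3)oc2c1` — 1630 nM
compound 3 `CCN(CC)c1ccc2cc(C(=O)c3ccc(N4CCN(C(=O)CN5CCN(S(=O)(=O)c6ccc(C#N)cc6)CC5)CC4)cc3)oc2c1` — > 40000 nM

All three were tested in a functional assay on SGC-7901 cells (Homo sapiens) for cytotoxicity, read by MTT assay, with a stated time of 48 h; on this read-out lower numbers stand for stronger inhibition and higher numbers for weaker inhibition. Of the two numbers shown, compound 1 sits at the low end, though a 1.3-fold higher number from compound 1 to compound 2 (0.13 log units; within the scatter) keeps the two within the scatter. For compound 3 the assay reports only a limit, not a number. Compound 3 sits at the limit of > 40000 nM in this assay, at which 1 of the 3 values shown sits. Accordingly an at least 32-fold higher number from compound 1 to compound 3 (1.51 log units; beyond the scatter) and an at least 24-fold higher number from compound 2 to compound 3 (1.38 log units; beyond the scatter) are both large losses.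

The unmeasured compound 4 `CCN(CC)c1ccc2cc(C(=O)c3ccc(N4CCN(C(=O)CN5CCN(CC(C)=O)CC5)CC4)cc3)oc2c1` differs from compound 1 by 2-oxopropyl in place of hydrogen on an amine nitrogen in a ring. Among the measured compounds shown here, two measured steps bear on this position. Placing the (chloromethyl)carbonyl there gave a 1.3-fold higher number from compound 1 to compound 2 (0.13 log units; within the scatter), within the scatter. Placing the (4-cyanophenyl)sulfonyl there gave an at least 32-fold higher number from compound 1 to compound 3 (1.51 log units; beyond the scatter), a large loss. The 2-oxopropyl is closer in size to the first of these groups than to the second, so the step from compound 1 to compound 4 in this assay is expected to be small, at most a modest rise in the number, and plausibly within the scatter, as an estimated 1.2-fold higher number from compound 1 to compound 4 (0.09 log units; within the scatter).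

Compound 4 is therefore estimated at 1500 nM, with a range from 600 nM to 4000 nM.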

Compound 4, half-maximal inhibitory concentration: 2210 nM
The estimate for compound 4 lay 1.5-fold (0.17 log units) below the measured number; low and high end bracket the measured number.
By their numbers in this assay, from the lowest: compounds 1, 2 and 4 (each within the scatter of the next). At a limit, above all of these: compound 3.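

With compound 4, a third group on this amine nitrogen in a ring stays within the scatter of hydrogen in this assay (a 1.8-fold higher number from compound 1 to compound 4 (0.26 log units; within the scatter)) and of the (chloromethyl)carbonyl (a 1.4-fold higher number from compound 2 to compound 4 (0.13 log units; within the scatter)), so neither the free hydrogen nor the chlorine-bearing group is needed for a number of this order. Among the four compounds, only compound 3 goes against this pattern, and the large gap to the 2-oxopropyl (an at least 18-fold lower number from compound 3 to compound 4 (1.25 log units; beyond the scatter)) ties the loss to the (4-cyanophenyl)sulfonyl rather than to substitution of this nitrogen as such. Compound 3 stands at a limit and not at a number, so that gap has no upper end: the limit of > 40000 nM in this assay, at which 1 of the 4 values shown sits.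

Going by these compounds, whether the loss in compound 3 belongs to the sulfonyl or to the 4-cyanophenyl stays open, and a methylsulfonyl or a 4-cyanobenzoyl on this nitrogen would separate the two. Also open, on these data alone, is how far the tolerance at this nitrogen reaches, for instance with a longer chain ending in an amine or a carboxylic acid, and whether any such group would give a number clearly below that of compound 1.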